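Swapping the selenium-bearing group of compound 3

The compounds below may be only part of what the source reports. "The series", "measured", "known", "first", "only" and "open" are said of these compounds alone.

compound 1 `COc1ccc(N(C)c2nc(C)nc3ccccc23)cc1OCCC[Se]C#N` gives 921 nM
compound 2 `COc1ccc(N(C)c2nc(C)nc3ccccc23)cc1C(=O)NCC[Se]C#N` gives 561 nM
compound 3 `COc1ccc(N(C)c2nc(C)nc3ccccc23)cc1C(=O)OCCCC[Se]C#N` gives 1080 nM

These three values come from a functional assay on LoVo cells (Homo sapiens) for inhibition, read by MTT assay, with a stated time of 48 h (a lower number here means a stronger inhibitor, a higher number a weaker inhibitor), and lie close together. Compound 3 (1080 nM) stands within the scatter of both other compounds. Its two measured steps are a 1.2-fold higher number from compound 1 to compound 3 (0.07 log units; within the scatter) and a 1.9-fold higher number from compound 2 to compound 3 (0.28 log units; within the scatter) and neither separates it from the others.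

The next compound, compound 4 `COc1ccc(N(C)c2nc(C)nc3ccccc23)cc1OCCCCC[Se]C#N`, has not yet been measured. Its change from compound 3 is a group of 9 heavy atoms (6 carbon, 1 nitrogen, 1 oxygen, 1 selenium; no ring) in place of a group of 10 heavy atoms (6 carbon, 1 nitrogen, 2 oxygen, 1 selenium; no ring), on an aromatic carbon and the site is ortho to a methoxy group. Within the data shown here, the measured series offers no direct precedent for this exact exchange, but three steps bear on it, as each replaces the selenium-bearing group. Besides the two already given there is a 1.6-fold lower number from compound 1 to compound 2 (0.22 log units; within the scatter) and this one also stays within the scatter. None of the three moved the number beyond the scatter in this assay and so no step beyond it is expected here. The estimated step is a 1.1-fold lower number from compound 3 to compound 4 (0.06 log units; within the scatter) and it is expected to remain inside the scatter. Compound 4 is expected at 950 nM with an estimated range from 450 nM to 1900 nM in this assay.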

Compound 4, half-maximal inhibitory concentration: 5210 nM
For compound 4 the middle estimate is 5.5-fold (0.74 log units) below the measured one; measured number above the stated range.
By their numbers in this assay, from the lowest: compounds 2, 1 and 3 (each within the scatter of the next); then compound 4.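

Until compound 4, every exchange of the selenium-bearing group on this aromatic carbon, ortho to a methoxy group, had stayed within the scatter in this assay and the site looked tolerant of change. The new result shows that it is not, with a 4.8-fold higher number from compound 3 to compound 4 (0.68 log units; beyond the scatter) and a 9.3-fold higher number from compound 2 to compound 4 (0.97 log units; beyond the scatter) making compound 4 the weakest inhibitor of the four. The pair that keeps the oxygen on the aromatic ring is the most telling, since only the chain grows there, and a 5.7-fold higher number from compound 1 to compound 4 (0.75 log units; beyond the scatter) shows that a longer chain alone, with no carbonyl involved, is enough to move the number beyond the scatter; no measurement available here bears on why this happens.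

As far as these compounds go, whether the number climbs gradually or abruptly between the chains of compound 1 and compound 4 stays open, as does whether a still longer chain on the aromatic oxygen would raise it further. Also open, from the compounds shown here alone, is whether an amide carrying the chain of compound 4, or sulfur in place of selenium, would behave in the same way.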